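Bromo to iodo: one swap across three measured compounds

The source may report more compounds than this note shows. Statements on the series, on what has been measured and on what is new or still open speak of the compounds shown alone.

Measured compounds:
compound 1 `C[C@H](NC(=O)Nc1ccccc1Br)c1ccccc1` gives 101%
compound 2 `C[C@@H](NC(=O)Nc1ccc(Br)cc1)c1ccccc1` gives 100%
compound 3 `C[C@H](NC(=O)Nc1ccccc1I)c1ccccc1` gives 99%

For the measured compounds named here, all three were read in an ADME assay on the whole organism with Oryza sativa as the target, tested at 0.1 uM (on this read-out lower numbers stand for a stronger effect and higher numbers for a weaker effect at the one concentration tested), and the three values lie within the usual scatter of one another, so no compound stands apart from the others on this read-out.

Compound 1 and compound 3 differ by one change, (iodo in place of bromo on an aromatic carbon). The step made is a number 2 percentage points lower from compound 1 to compound 3 (within the scatter).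

Compound 2 has the same atoms as compound 1 joined differently; the difference between the two cores is not broken down here. Compound 4 `C[C@@H](NC(=O)Nc1ccc(I)cc1)c1ccccc1` is not yet measured. It differs from compound 2 by iodo in place of bromo on an aromatic carbon. This is the same kind of change as from compound 1 to compound 3, but the surroundings of the place differ: ortho to a large group in the first pair, para to a large group in the second.

The step from compound 2 to compound 4 in this assay is expected to be no change at the digits printed from compound 2 to compound 4 (within the scatter), because a number 2 percentage points lower from compound 1 to compound 3 (within the scatter) stayed within the scatter. For compound 4 the expected value is 100%, estimated to fall between 93% and 106%.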

Compound 4, a percentage reported as activity, at one concentration (the size of the read-out at that concentration, not a potency): 100%
Estimate against measurement, compound 4: no gap at the digits printed; low and high end bracket the measured number.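

In this assay, iodo in place of bromo on an aromatic carbon para to a large group gives no change at the digits printed from compound 2 to compound 4 (within the scatter). Set beside the earlier step, the swap reads the same on both cores, with no gap that can be told from noise: the same change on two cores in this assay, a number 2 percentage points lower (within the scatter) from compound 1 to compound 3 and no change at the digits printed (within the scatter) from compound 2 to compound 4, 2 percentage points apart, within the scatter of two such steps

For the compounds shown here, both steps stay within the scatter, so their agreement shows only that this swap leaves no visible mark at the one concentration tested on these two cores; it does not show that the swap would stay silent on a core or at a concentration where the read-out moves.

The compounds shown carry only bromo or iodo as the halogen on that aromatic ring, which leaves open whether an amine or a carboxylic acid at the same place would shift the read-out. Also open, on these data alone, is whether a longer chain in place of the methyl group would shift it.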